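The source may report more compounds than this note shows. Statements on the series, on what has been measured and on what is new or still open speak of the compounds shown alone.

Working notes on the aryl-urea series in an assay on isolated protein for inhibition of serine/threonine-protein kinase TNNI3K (Homo sapiens); a lower number here means a stronger inhibitor, a higher number a weaker inhibitor.

Three compounds share the urea core and differ only in the group on the ether oxygen. Compound 1 `O=C(Nc1ccc(Oc2cc(O)ncn2)cc1)Nc1cccc(C(F)(F)F)c1` gives 3200 nM. Compound 2 `CC(C)Nc1cc(Oc2ccc(NC(=O)Nc3cccc(C(F)(F)F)c3)cc2)ncn1` gives 40 nM. Compound 3 `CN(C)c1cc(Oc2ccc(NC(=O)Nc3cccc(C(F)(F)F)c3)cc2)ncn1` gives 2500 nM. Compound 3 therefore stands second highest of the three numbers: against compound 1 the gap is within the scatter, a 1.3-fold lower number from compound 1 to compound 3 (0.11 log units; within the scatter), while against compound 2 it is large, a 63-fold higher number from compound 2 to compound 3 (1.80 log units; beyond the scatter).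

Compound 4 `CNc1nccc(Oc2ccc(NC(=O)Nc3cccc(C(F)(F)F)c3)cc2)n1` is not yet measured. Relative to compound 3 the change is 2-(methylamino)pyrimidin-4-yl in place of 6-(dimethylamino)pyrimidin-4-yl on an oxygen on an aromatic ring. The measured steps that bear on this are the two involving compound 2: an 80-fold lower number from compound 1 to compound 2 (1.90 log units; beyond the scatter) and a 63-fold higher number from compound 2 to compound 3 (1.80 log units; beyond the scatter). Both show that an amino group bearing a hydrogen on nitrogen, as in the isopropylamino of compound 2, went with a much lower number than either hydroxy or dimethylamino. The methylamino that enters in compound 4 again carries such a hydrogen, but it sits on a different position of the ring and is smaller than isopropylamino, so a full return to the level of compound 2 is not assumed.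

For compound 4 a step of an 8.3-fold lower number from compound 3 to compound 4 (0.92 log units; beyond the scatter) is expected, a lower number beyond the scatter, giving an estimate of 300 nM with a range from 60 nM to 1500 nM.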

Compound 4, half-maximal inhibitory concentration: 50 nM
Compound 4: the middle estimate sits 6.0-fold (0.78 log units) above what was measured; measured number below the stated range.
By their numbers in this assay, from the lowest: compounds 2 and 4 (each within the scatter of the next); then compounds 3 and 1 (each within the scatter of the next).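

In this assay, the change to 2-(methylamino)pyrimidin-4-yl gives a 50-fold lower number from compound 3 to compound 4 (1.70 log units; beyond the scatter), and a 64-fold lower number from compound 1 to compound 4 (1.81 log units; beyond the scatter) is of similar size, so a group other than isopropylamino, at a different place in its name, also reaches the low level. The remaining step is a 1.3-fold higher number from compound 2 to compound 4 (0.10 log units; within the scatter), so neither the isopropylamino chain nor the 6-position in 6-(isopropylamino)pyrimidin-4-yl is required for that level; among the four compounds, the two with an amino group bearing a hydrogen on nitrogen have the low numbers, while compound 1 also carries a hydrogen-bond donor in its hydroxy group and goes against any reading based on a donor alone. Nothing measured here gives a reason for these steps.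

Compound 4 changes both the place of the amino group and its substituents, so the contribution of each stays unresolved; 2-(dimethylamino)pyrimidin-4-yl and 6-(methylamino)pyrimidin-4-yl would separate the two. The compounds shown also leave open how a plain amino group or a longer chain such as butylamino would compare.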